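The source may report more compounds than this note shows. Statements on the series, on what has been measured and on what is new or still open speak of the compounds shown alone.

Measured so far in a functional assay for activation of Alpha-1B adrenergic receptor (Homo sapiens), read by calcium flux; a higher number here means that more compound is needed for the effect, a lower number that less compound is needed: compound 1 `c1cnc(-c2ccccc2OCC2=NCCN2)nc1`, which gives only the limit < 100000 nM. Compound 2 `c1coc(-c2ccccc2OCC2=NCCN2)c1`, which gives 10 nM. Compound 3 `c1c[nH]c(-c2ccccc2OCC2=NCCN2)c1`, which gives 1 nM.

Compound 1 stands at the limit of this assay, with no number of its own: the limit of < 100000 nM in this assay, at which 1 of the 3 values shown sits. The change to compound 4 `c1ccc(-c2nccs2)c(OCC2=NCCN2)c1` is 1,3-thiazol-2-yl in place of pyrimidin-2-yl on an aromatic carbon. For the measured compounds named here, compound 1 gives only a limit, so the steps a step that the limit leaves unreadable from compound 1 to compound 2 and a step that the limit leaves unreadable from compound 1 to compound 3 carry no readable size, and no measured step shares the same change. Going by the values given here, the one readable step, a 10-fold lower number from compound 2 to compound 3 (1.00 log units; beyond the scatter), shows that exchanging furan-2-yl for 1H-pyrrol-2-yl shifts the number modestly. Compound 4 carries a ring more like those of compounds 2 and 3 than the pyrimidin-2-yl of compound 1, so an expected step that the limit leaves unreadable from compound 1 to compound 4 follows, taking it well off the limit. Compound 4 is expected to give about 100 nM, within 10 nM to 3000 nM.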

Compound 4, half-maximal effective concentration: 20 nM
The estimate for compound 4 lay 5.0-fold (0.70 log units) above the measured number; measured number inside the range.
By their numbers in this assay, from the lowest: compound 3; then compounds 2 and 4 (each within the scatter of the next).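

On this aromatic carbon, 1,3-thiazol-2-yl, with its sulfur, does about as well as furan-2-yl, with a 2.0-fold higher number from compound 2 to compound 4 (0.30 log units; within the scatter). Against 1H-pyrrol-2-yl it loses clearly, with a 20-fold higher number from compound 3 to compound 4 (1.30 log units; beyond the scatter), so among these five-membered rings compound 3 stands apart. The steps from compound 1 cannot be read, because compound 1 gives only a limit: the limit of < 100000 nM in this assay, at which 1 of the 4 values shown sits.

Still open, from the compounds shown here alone, is whether ring size or the ring's atoms decide the result at this place. A phenyl or pyridin-2-yl group there would help separate the two.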